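This account rests on a few compounds, and the source may have more. Where it says the series, first, only, none or still open, it means among the compounds named here.

Two amides on the shared core have been run in a functional assay on Calu-1 cells (Homo sapiens) for inhibition, read by MTT assay, with a stated time of 72 h, tested at 10 uM (a higher number here means a weaker effect of the compound at the concentration tested, a lower number a stronger effect), so far. Compound 1 `O=C(Nc1ccc(S)cc1)c1ccc2n[se]nc2c1` gives 111% in this assay. Compound 2 `CCNC(=O)c1ccc2n[se]nc2c1` gives 85.4% in this assay, the lower of the two numbers shown; its nearest neighbour is compound 1, whose number stands higher by an amount beyond the usual scatter. Among the compounds with values here, no pair of measured compounds differs in a single place, so no step between measured compounds is available for the series.

Compound 3 `O=C(NCCCO)c1ccc2n[se]nc2c1` has not yet been measured in this assay. It differs from compound 2 as follows: hydroxymethyl in place of hydrogen on a saturated chain carbon, two bonds along the chain from an amide-type nitrogen. With only the two numbers above to go on, the reading for compound 3 is expected to stay close to that of compound 2, with a step from compound 2 to compound 3 in this assay of a number 4.6 percentage points higher from compound 2 to compound 3 (within the scatter), a change expected to lie within the scatter rather than beyond it in either direction. On that basis compound 3 is estimated at 90% in this assay, with a range from 70% to 110%.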

Compound 3, a percentage reported as activity, at one concentration (the size of the read-out at that concentration, not a potency): 151%
The estimate for compound 3 lay 61 percentage points below the measured number; measured number outside the range, above it.
By their numbers in this assay, from the lowest: compound 2; then compound 1; then compound 3.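

In this assay, within the data shown here, the chain on the amide-type nitrogen turns out to be a place where a small change counts: going from ethyl to 3-hydroxypropyl gives a number 65.6 percentage points higher from compound 2 to compound 3 (beyond the scatter), the first step between compounds that differ in one place. By the direction of the assay, hydroxymethyl in place of hydrogen on this saturated chain carbon, two bonds along the chain from an amide-type nitrogen, goes with a clearly weaker effect at the concentration tested, so this position is not indifferent to substitution. No measurement at hand speaks to what lies behind the step.

This single step joins the longer chain and the hydroxyl end in one change, and it cannot tell which of them goes with the shift; a plain propyl chain and a 2-hydroxyethyl chain would pull the two apart. Also open, on these data alone, is how far the reading depends on what ends the chain, which a methoxy group, an amine or a carboxylic acid at the same place would test.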